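Urea series: fluorophenyl in place of methylphenyl

This account rests on a few compounds, and the source may have more. Where it says the series, first, only, none or still open, it means among the compounds named here.

Three ureas have been measured in a functional assay on A549 cells (Homo sapiens) for antiproliferative activity, read by MTT assay; a higher number here means a weaker inhibitor, a lower number a stronger inhibitor. Compound 1 `Cc1ccccc1NC(=O)Nc1cccc(CNc2ncnc3ccccc23)c1` gives 40200 nM, compound 2 `O=C(Nc1cccc(CNc2ncnc3ccccc23)c1)Nc1ccccc1Cl` gives 18000 nM, and compound 3 `COc1cc2ncnc(NCc3cccc(NC(=O)Nc4cccc(C)c4)c3)c2cc1OC` gives 27100 nM. Compound 3 holds the second highest of the three numbers, but its distance to compound 1 and to compound 2 lies within the scatter, so no order is claimed from its side. Among the compounds with values here, the only measured step, a 2.2-fold lower number from compound 1 to compound 2 (0.35 log units; beyond the scatter), exchanges chloro for methyl on an aromatic carbon and is modest but beyond the scatter.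

Compound 4 `COc1cc2ncnc(NCc3cccc(NC(=O)Nc4ccccc4F)c3)c2cc1OC` differs from compound 3 by 2-fluorophenyl in place of 3-methylphenyl on an amide-type nitrogen. As in the measured step, a methylphenyl gives way to a halophenyl on the urea nitrogen, so the step from compound 1 to compound 2 is the one that bears on it. That step brought in chloro rather than fluoro, and the entering ring here also differs in the name of its substituent pattern, so only a smaller shift in the same direction is expected for compound 4, a 1.5-fold lower number from compound 3 to compound 4 (0.18 log units; within the scatter), possibly not beyond the scatter. Compound 4 is thus estimated at 18000 nM in this assay, with a range from 7000 nM to 42000 nM.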

Compound 4, half-maximal inhibitory concentration: 23800 nM
Compound 4: middle estimate off by 1.3-fold (0.12 log units), on the low side; the measured number falls inside the stated range.
By their numbers in this assay, from the lowest: compounds 2, 4, 3 and 1 (each within the scatter of the next, the first and the last beyond it).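

On the core of compound 3, in this assay, 2-fluorophenyl in place of 3-methylphenyl on an amide-type nitrogen gives a 1.1-fold lower number from compound 3 to compound 4 (0.06 log units; within the scatter) and so leaves the read-out within the scatter. This exchange alters both the substituent and its printed ring position, yet neither compound can be set apart from the other here. The earlier step, a 2.2-fold lower number from compound 1 to compound 2 (0.35 log units; beyond the scatter) on the core of compound 1, stays beyond the scatter, but it involves a different core and a different halogen, and no measured evidence accounts for the result at this position.

The compounds shown do not separate the effect of the fluoro group from that of its ring position on the core of compound 3. Also open, from the compounds shown here alone, is how this position responds to an aryl ring bearing an amine or a carboxylic acid, or to a longer chain in place of the ring.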